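A few compounds are considered here, and "the series" means these few. Any claim that something is new, unique, unknown or untested is made for them only; others in the source may bear on it.

Measured in a functional assay on HeLa cells (Homo sapiens) for antiproliferative activity, read by sulforhodamine B assay, with a stated time of 48 h; on this read-out higher numbers stand for weaker inhibition of growth and lower numbers for stronger inhibition of growth:
compound 1 `O=C1COc2ccccc2N1CCCn1cc(-c2ccccc2)nn1`: 9000 nM
compound 2 `Cc1ccc(-c2cn(CCCN3C(=O)COc4ccccc43)nn2)cc1`: 14300 nM
compound 3 `O=C1COc2ccccc2N1CCCn1cc(-c2ccccn2)nn1`: 10000 nM

Compound 3 lies within the scatter of the other two compounds: a 1.1-fold higher number from compound 1 to compound 3 (0.05 log units; within the scatter), and a 1.4-fold lower number from compound 2 to compound 3 (0.16 log units; within the scatter).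

Compound 4 `O=C1COc2ccccc2N1CCCn1cc(-c2cccnc2)nn1` has not yet been measured. Its difference from compound 3 is pyridin-3-yl in place of pyridin-2-yl on an aromatic carbon.

Going by the values given here, no measured step covers this exchange directly. The closest evidence comes from other changes to the aromatic group at the same place. Pyridin-2-yl in place of phenyl gave a 1.1-fold higher number from compound 1 to compound 3 (0.05 log units; within the scatter), methyl in place of hydrogen gave a 1.6-fold higher number from compound 1 to compound 2 (0.20 log units; within the scatter), and pyridin-2-yl in place of 4-methylphenyl gave a 1.4-fold lower number from compound 2 to compound 3 (0.16 log units; within the scatter). None of these three steps exceeds the scatter, though three compounds are a thin basis.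

No change beyond the scatter is therefore expected in this assay, and the expected step is no change at the digits printed from compound 3 to compound 4 (within the scatter). For compound 4 the estimated value is 10000 nM, with an expected range of 5500 nM to 18000 nM.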

Compound 4, concentration for 50% growth inhibition: > 100000 nM
Compound 4 was reported as a limit; the forecaster's own chance of this, stated with the estimate: 5%; middle value at least 10-fold (1.00 log units) from the limit.
By their numbers in this assay, from the lowest: compounds 1, 3 and 2 (each within the scatter of the next). At a limit, above all of these: compound 4.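

In this assay, the aromatic group at this place, on an aromatic carbon of a five-membered aromatic ring with 3 nitrogen, had so far shown only steps within the scatter, but moving from pyridin-2-yl to pyridin-3-yl, with the same atoms joined differently, goes beyond it: an at least 10-fold higher number from compound 3 to compound 4 (1.00 log units; beyond the scatter). The other two exchanges to pyridin-3-yl also go beyond the scatter, an at least 6.9-fold higher number from compound 2 to compound 4 (0.84 log units; beyond the scatter) and an at least 11-fold higher number from compound 1 to compound 4 (1.04 log units; beyond the scatter), so pyridin-3-yl stands apart from phenyl, 4-methylphenyl and pyridin-2-yl here. The result for compound 4 is a limit, not a number: the limit of > 100000 nM in this assay, at which 1 of the 4 values shown sits.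

Going by these compounds, the true size of these steps therefore stays open, with only a lower bound known. Also open, on these data alone, is how pyridin-4-yl, or an amine or a carboxylic acid on the pyridin-3-yl group, would behave at this place.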